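Bromo for methoxy on the core of compound 3

This account rests on a few compounds, and the source may have more. Where it says the series, first, only, none or still open, it means among the compounds named here.

Of the compounds shown here, three have been measured in a functional assay on MDA-MB-231 cells (Homo sapiens) for cytotoxicity; a higher number here means a weaker inhibitor, a lower number a stronger inhibitor. Compound 1 `COc1ccc(Cn2cc(/C=N\NC(=O)c3c[nH]c4ccccc34)c3cc(OC)ccc32)cc1` gives 9800 nM, compound 2 `COc1ccc2c(c1)c(/C=N\NC(=O)c1c[nH]c3ccc(Br)cc13)cn2Cc1ccc(Cl)cc1` gives 5000 nM, and compound 3 `COc1ccc2c(c1)c(/C=N\NC(=O)c1c[nH]c3ccccc13)cn2Cc1ccc(Cl)cc1` gives 82700 nM. Compound 3 thus stands as the weakest of the three: compound 1 is its nearest neighbour, and the step of an 8.4-fold higher number from compound 1 to compound 3 (0.93 log units; beyond the scatter) came with chloro in place of methoxy on an aromatic carbon; the step of a 17-fold higher number from compound 2 to compound 3 (1.22 log units; beyond the scatter) came with hydrogen in place of bromo on an aromatic carbon.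

Compound 4 `O=C(N/N=C\c1cn(Cc2ccc(Cl)cc2)c2ccc(Br)cc12)c1c[nH]c2ccccc12` differs from compound 3 by bromo in place of methoxy on an aromatic carbon. Neither measured step bears on this change directly. The step of a 17-fold higher number from compound 2 to compound 3 (1.22 log units; beyond the scatter) shows that a bromo on a different part of the shared core mattered, but it did not replace a methoxy there, and the step of an 8.4-fold higher number from compound 1 to compound 3 (0.93 log units; beyond the scatter) concerns a different ring. The size and direction of the coming step are therefore uncertain; a modest change in either direction seems as likely as none beyond the scatter. Compound 4 is expected to give about 40000 nM, within a range from 8000 nM to 200000 nM, which means an expected step of a 2.1-fold lower number from compound 3 to compound 4 (0.32 log units; beyond the scatter).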

Compound 4, half-maximal inhibitory concentration: 1000 nM
For compound 4 the middle estimate is 40-fold (1.60 log units) above the measured one, and the stated range ends above it.
By their numbers in this assay, from the lowest: compound 4; then compounds 2 and 1 (each within the scatter of the next); then compound 3.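

Within the data shown here, all three earlier compounds carried methoxy at this place on the core, so compound 4 is the first to show what a change there does, and in this assay the exchange for bromo gives an 83-fold lower number from compound 3 to compound 4 (1.92 log units; beyond the scatter). The position, on the carbon-only six-membered aromatic ring of the fused system, is therefore not indifferent to its substituent in this series. The step also runs the same way as a 17-fold higher number from compound 2 to compound 3 (1.22 log units; beyond the scatter), where the bromo sits elsewhere in the molecule: in both pairs, the compound with the bromo has the lower number. Nothing available explains this difference.

Since this single exchange removes methoxy and brings in bromo together, the compounds shown leave open how much of the step belongs to the loss of the one and how much to the arrival of the other, a question that hydrogen, chloro or an amine at this position would address. They also leave open whether bromo at this position and bromo at the place it occupies in compound 2 would act together in one molecule.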